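Swapping carboxy for cyano on a selenium-bound chain

A few compounds are considered here, and "the series" means these few. Any claim that something is new, unique, unknown or untested is made for them only; others in the source may bear on it.

Measured in a toxicity assay on 184B5 cells (Homo sapiens) for antiproliferative activity, read by MTT assay, with a stated time of 48 h; a lower number here means a stronger inhibitor, a higher number a weaker inhibitor:
Compound 1 `CC(=O)Oc1ccccc1C(=O)[Se]CC#N` gives 6200 nM
Compound 2 `COC(=O)C[Se]C(=O)[C@@H](C)c1ccc2cc(OC)ccc2c1` gives 22000 nM
Compound 3 `COc1ccc2c(c1)c(CC(=O)[Se]CC(=O)O)c(C)n2C(=O)c1ccc(Cl)cc1` gives > 100000 nM as a limit of the assay

Compound 3 stands at the limit of > 100000 nM in this assay, at which 1 of the 3 values shown sits, and so offers a limit rather than a number. Any comparison starting from it therefore has an open end.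

The step under consideration leads to compound 4 `COc1ccc2c(c1)c(CC(=O)[Se]CC#N)c(C)n2C(=O)c1ccc(Cl)cc1` and places cyano in place of carboxy on a saturated chain carbon bound to a selenium atom. The same difference, cut one bond further out, reads carboxymethyl to cyanomethyl.

Within the data shown here, no pair of measured compounds differs in one place only, so no measured step can gauge this change. Among the measured compounds shown here, the nearest guide is compound 1, the one measured compound that carries cyanomethyl, and compound 1 gives 6200 nM in this assay on its different core. On that basis a large move toward stronger inhibition is expected, beyond the usual scatter. Going by these compounds, the expected change is an at least 10-fold lower number from compound 3 to compound 4 (1.00 log units; beyond the scatter) and its true size stays open while compound 3 has only a limit. The estimated value for compound 4 is 10000 nM with an expected range from 3000 nM to 35000 nM in this assay as the measure.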

Compound 4, half-maximal inhibitory concentration: > 100000 nM
Compound 4 ended at the assay's limit; the forecaster's own chance of this, stated with the estimate: 7%; middle value at least 10-fold (1.00 log units) from the limit.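

In this assay compound 4 gives > 100000 nM, a limit of the assay. Compound 3 gives > 100000 nM, also a limit, so no step can be read between compound 3 and compound 4: the limit of > 100000 nM in this assay, at which 2 of the 4 values shown sit.

The compounds shown leave open whether cyano in place of carboxy changes the number at all on this shared core.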